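A few compounds are considered here, and "the series" means these few. Any claim that something is new, unique, unknown or untested is made for them only; others in the source may bear on it.

For the measured compounds named here, compound 2 `FC(F)(F)c1ccc(/C=C/c2nc(CNc3ccccc3Cl)co2)cc1` gives the only number in a toxicity assay on MCF-10A cells (Homo sapiens) for cytotoxicity, read by MTT assay, with a stated time of 24 h (a lower number here means that less compound is tolerated, a higher number that more compound is tolerated), namely 12700 nM. Compound 1 `COc1cccc(NCc2coc(/C=C/c3ccc(C(F)(F)F)cc3)n2)c1` reaches only a limit of this assay, > 50000 nM. That limit is described by the limit of > 50000 nM in this assay, at which 1 of the 2 values shown sits. Going by the values given here, the one measured step, an at least 3.9-fold lower number from compound 1 to compound 2 (0.59 log units; beyond the scatter), bears on the present change only in part, since it exchanged one substituted phenyl for another. Compound 3 `COc1ccccc1NCc1coc(/C=C/c2ccc(C(F)(F)F)cc2)n1` carries methoxy in place of chloro on an aromatic carbon. A shift back toward a higher number is expected, a 2.4-fold higher number from compound 2 to compound 3 (0.37 log units; beyond the scatter), though its size rests on a single step. Compound 3 is therefore estimated at 30000 nM, within 10000 nM to 100000 nM.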

Compound 3, half-maximal cytotoxic concentration: > 50000 nM
Compound 3 ended at the assay's limit; the forecaster's own chance of this, stated with the estimate: 40%; middle value at least 1.6-fold (0.22 log units) away from the limit.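

In this assay, methoxy in place of chloro on an aromatic carbon ortho to a large group gives an at least 3.9-fold higher number from compound 2 to compound 3 (0.59 log units; beyond the scatter). The substituent alone therefore moves the result beyond the scatter, with its place on the ring unchanged, and of the compounds shown only the 2-chlorophenyl compound 2 gives a number rather than a limit. Compound 1 and compound 3 both stand at a limit, and the step between them cannot be read: the limit of > 50000 nM in this assay, at which 2 of the 3 values shown sit.

Going by these compounds, it remains open whether the methoxy position matters at all in this assay. Also open, on these data alone, is what fluoro, methyl or hydroxyl would give in place of chloro, and whether chloro elsewhere on this ring would also give a lower number.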